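From methoxycarbonyl to cyclohexyloxycarbonyl on a shared core

A few compounds are considered here, and "the series" means these few. Any claim that something is new, unique, unknown or untested is made for them only; others in the source may bear on it.

In a toxicity assay on NIH3T3 cells (Mus musculus) for cytotoxicity, read by resazurin assay (a lower number here means that less compound is needed, a higher number that more compound is needed for the effect), compound 1 `N#Cc1ccc(NCc2cncn2Cc2ccc(-c3ccccc3)cc2)cc1-c1ccccc1` gives > 1000 nM, which is a limit of the assay and not a number. Compound 2 `COC(=O)c1ccc(NCc2cncn2Cc2ccc(-c3ccccc3)cc2)cc1-c1ccccc1`, which carries methoxycarbonyl in place of cyano on an aromatic carbon, gives > 1000 nM, again only a limit. Compound 2 therefore has no numerical position in this assay. Among the compounds with values here, the one measured step that bears on the next change is a step that the two limits leave unreadable from compound 1 to compound 2, and it offers no size to carry forward. Within the data shown here, the only other evidence is the limit of > 1000 nM in this assay, at which 2 of the 2 values shown sit.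

Compound 3 `O=C(OC1CCCCC1)c1ccc(NCc2cncn2Cc2ccc(-c3ccccc3)cc2)cc1-c1ccccc1` has cyclohexyl in place of methyl on an oxygen next to a carbonyl group. Among the measured compounds shown here, no measured step covers this exchange, so no change beyond the scatter is expected in this assay, and no direction can be firmly assigned. A further limit is the most likely report. The expected step is a step that the limit leaves unreadable from compound 2 to compound 3, which is only an estimate set against a limit. Compound 3 is estimated at 1500 nM, with an expected range from 600 nM to 5000 nM.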

Compound 3, half-maximal effective concentration: > 10000 nM
Compound 3: no number, only a limit (the forecaster's own chance of this, stated with the estimate: 75%); middle value at least 6.6-fold (0.82 log units) from the limit.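

In this assay compound 3 gives > 10000 nM, which is a limit and not a number. Within the data shown here, compound 1 and compound 2 also stand only as limits, so no step among the three compounds can be read. The compounds shown leave open what concentration any of them needs for the effect, and whether cyclohexyl in place of methyl changes it.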